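The compounds below may be only part of what the source reports. "The series", "measured", "known", "first", "only" and "open" are said of these compounds alone.

Series notes, antiproliferative screen.

Of the compounds shown here, three have been measured so far. Compound 1 `CCC(C)n1cnc2c(NCc3ccc(C(=O)Nc4ccccc4N)cc3)nc(Cl)nc21` serves as the reference point: in a functional assay on HCT-116 cells (Homo sapiens) for antiproliferative activity, read by CCK-8 assay, with a stated time of 72 h, tested at 2 uM (a higher number here means a stronger effect of the compound at the concentration tested, a lower number a weaker effect), compound 1 gives 74.6%. Compound 2 `Cc1ccc(Nc2nc(Cl)nc3c2ncn3Cc2ccc(/C=C/C(=O)Nc3ccccc3N)cc2)cc1` gives 0.27% in this assay, and compound 3 `CCCCn1cnc2c(Nc3ccccc3)nc(NCOCc3ccc(/C=C/C(=O)Nc4ccccc4N)cc3)nc21` gives 6.58% in this assay. Compound 1 therefore stands highest of the three numbers, with compound 3 nearest and compound 2 furthest, and both gaps lie beyond the usual scatter. No pair among these three differs in a single place, so neither gap can be tied to one structural change.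

The next compound, compound 4 `Nc1ccccc1NC(=O)c1ccc(CNc2nc(Cl)nc3c2ncn3Cc2ccccc2)cc1`, is derived from compound 1 by a single change: benzyl in place of sec-butyl on an aromatic nitrogen The amide portion of compound 1 and the rest of the shared core are unchanged.

Among the measured compounds shown here, no measured step of this kind exists in the set, so the expectation for compound 4 rests on compound 1 alone, whose value of 74.6% is the only one obtained with this arrangement of the amide. A modest decrease is expected, a number 16.6 percentage points lower from compound 1 to compound 4 (beyond the scatter), without firm ground for its size. Compound 4 is estimated at 58% in this assay, within a range from 25% to 85%.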

Compound 4, a percentage reported as inhibition, at one concentration (the size of the read-out at that concentration, not a potency): 7.7%
The estimate for compound 4 lay 50.3 percentage points above the measured number, outside the stated range (below it).
By their numbers in this assay, from the lowest: compounds 2, 3 and 4 (each within the scatter of the next); then compound 1.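

Among the compounds shown here, the step of a number 66.9 percentage points lower from compound 1 to compound 4 (beyond the scatter) is the first single-place comparison, and it shows that in this assay the group on the aromatic nitrogen of the five-membered ring matters a great deal: benzyl in place of sec-butyl removes most of the read-out at the concentration tested, while the amide portion and the rest of the shared core stay the same. That amide arrangement is therefore not enough by itself for a high number, since compound 4 carries it and gives 7.7%; in this pair, the high number is found only with sec-butyl at this position. No available measurement bears on the cause of this step.

For the compounds shown here, only two groups can be compared at this position, so it remains open whether the drop goes with the aromatic ring of benzyl or with the larger count of heavy atoms; a cyclohexylmethyl group or an unbranched pentyl chain on the same nitrogen would help separate the two. Also open, as far as these compounds go, is how a much smaller group, such as methyl, or a chain ending in an amine would read out at this position.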